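The source may hold more compounds than are shown below. What is called first, only, known or untested is meant among the compounds shown, and "the series" means these compounds.

Compound 1 `COc1ccc(-c2nc(Nc3ccc(S(N)(=O)=O)cc3)n3c(C)nnc3c2C#N)cc1OC`: 48 nM
Compound 2 `COc1ccc(-c2nc(Nc3ccc(S(N)(=O)=O)cc3)nc(-n3nc(C)cc3C)c2C#N)cc1OC`: 41 nM
Compound 3 `COc1ccc(-c2nc(Nc3ccc(S(N)(=O)=O)cc3)n3nnnc3c2C#N)cc1OC`: 39 nM

In a functional assay on HeLa cells (Homo sapiens) for inhibition, read by sulforhodamine B assay, with a stated time of 48 h (a higher number here means a weaker inhibitor, a lower number a stronger inhibitor), compound 2 gives 41 nM, the second highest of the three numbers. Its nearest neighbour is compound 3 with 39 nM, a gap within the scatter, and its furthest is compound 1 with 48 nM, also within the scatter. The three compounds therefore sit together, although each carries a different group at the same place on the shared core.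

Compound 4 `CCOC1=NN(c2nc(Nc3ccc(S(N)(=O)=O)cc3)nc(-c3ccc(OC)c(OC)c3)c2C#N)C(=O)C1` has not yet been measured. It differs from compound 2 in one place: a group of 9 heavy atoms (5 carbon, 2 nitrogen, 2 oxygen; one five-membered non-aromatic ring with 2 hetero atoms) in place of a group of 7 heavy atoms (5 carbon, 2 nitrogen; one five-membered aromatic ring with 2 hetero atoms), on an aromatic carbon. Among the measured compounds shown here, no step between two measured compounds that differ in one place is available, so there is no measured guide for a change of this kind; the measured compounds only show that the groups tried so far at this position gave numbers within scatter of one another, and none of them carries a non-aromatic ring there. The step expected is a 1.7-fold higher number from compound 2 to compound 4 (0.23 log units; within the scatter), a small move toward a higher number that may not exceed the scatter. Compound 4 is estimated at 70 nM, with a range from 20 nM to 300 nM.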

Compound 4, half-maximal inhibitory concentration: 42 nM
Estimate against measurement, compound 4: 1.7-fold (0.22 log units) above; the measured number falls inside the stated range.
By their numbers in this assay, from the lowest: compounds 3, 2, 4 and 1 (each within the scatter of the next).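

In this assay, among the compounds shown here, placing the group of 9 heavy atoms with its five-membered non-aromatic ring where compound 2 carries 3,5-dimethyl-1H-pyrazol-1-yl gives a 1.0-fold higher number from compound 2 to compound 4 (0.01 log units; within the scatter) and so supplies the first readable step at this position. On this aromatic carbon, next to the ring nitrogen and ortho to a cyano group, an aromatic ring can thus be exchanged for a non-aromatic one that carries 2 oxygen atoms, without a change beyond the scatter. No measured property of either group is available to interpret this result.

The compounds shown leave open whether an open-chain amine, a carboxylic acid or a longer alkyl chain on this carbon would stay within the scatter of compound 2. They also leave open whether any group at this position can produce a step beyond the scatter.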